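Pyridin-4-yl for phenyl on the amide of compound 2

The compounds below may be only part of what the source reports. "The series", "measured", "known", "first", "only" and "open" are said of these compounds alone.

Measured so far:
compound 1 `CCCn1c(SCc2cc([N+](=O)[O-])ccc2OC)nc2cc(NC(=O)NC(C)(C)C)cc(C(=O)NC(C)(C)C)c21`: 490 nM
compound 2 `CCCn1c(SCc2cc([N+](=O)[O-])ccc2OC)nc2cc(NC(=O)NC(C)(C)C)cc(C(=O)NCc3ccccc3)c21`: 130 nM

In an assay on isolated protein for inhibition of Gonadotropin-releasing hormone receptor (Rattus norvegicus) (a higher number here means a weaker inhibitor, a lower number a stronger inhibitor), compound 2 gives the lowest of the two numbers, with compound 1 at 490 nM and a 3.8-fold lower number from compound 1 to compound 2 (0.58 log units; beyond the scatter). Compound 3 `CCCn1c(SCc2cc([N+](=O)[O-])ccc2OC)nc2cc(NC(=O)NC(C)(C)C)cc(C(=O)NCc3ccncc3)c21` carries pyridin-4-yl in place of phenyl on a saturated chain carbon bound to an amide-type nitrogen. Within the data shown here, no measured pair shows this exchange; the single step, a 3.8-fold lower number from compound 1 to compound 2 (0.58 log units; beyond the scatter), concerns a different part of the amide substituent and does not bear on it directly. No step beyond the scatter is therefore expected, and the estimated step is a 1.2-fold higher number from compound 2 to compound 3 (0.06 log units; within the scatter). For compound 3 in this assay the expected value is 150 nM, with a range from 50 nM to 450 nM.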

Compound 3, half-maximal inhibitory concentration: 35 nM
Compound 3: middle estimate off by 4.3-fold (0.63 log units), on the high side; the whole stated range lies above it.
By their numbers in this assay, from the lowest: compound 3; then compound 2; then compound 1.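

In this assay, the ring on the amide proves sensitive to a change from carbon to nitrogen alone: pyridin-4-yl in place of phenyl, with the saturated chain carbon kept, gives a 3.7-fold lower number from compound 2 to compound 3 (0.57 log units; beyond the scatter). Taken as a whole, (pyridin-4-yl)methyl in place of tert-butyl gives a 14-fold lower number from compound 1 to compound 3 (1.15 log units; beyond the scatter), so this position holds more range than the benzyl step alone showed. Nothing at hand accounts for the gain.

Open, as far as these compounds go, is whether pyridin-3-yl or pyridin-2-yl would match pyridin-4-yl. A longer chain between the amide nitrogen and the ring also remains untested in the compounds shown.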